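The source may hold more compounds than are shown below. What is called first, only, known or untested is meant among the compounds shown, and "the series" means these compounds.

Working notes on the series. In a functional assay on MGC-803 cells (Homo sapiens) for antiproliferative activity, read by CCK-8 assay, with a stated time of 72 h, tested at 8 uM (a lower number here means a weaker effect, a higher number a stronger effect of the compound at the concentration tested), compound 1 `Nc1ccccc1NC(=O)c1ccc(CSC(=S)N2CCN(c3ccccc3)CC2)cc1` gives 87.4%, compound 2 `CN(C(=S)SCc1ccc(C(=O)Nc2ccccc2N)cc1)c1cccnc1` gives 82.5% and compound 3 `COc1ccc(N2CCN(C(=S)SCc3ccc(C(=O)Nc4ccccc4N)cc3)CC2)cc1` gives 22.9%. Compound 2 therefore stands second of the three; against compound 1 the two numbers lie within the scatter, against compound 3 the gap is beyond it. Among the measured compounds shown here, the only single-place step measured, a number 64.5 percentage points lower from compound 1 to compound 3 (beyond the scatter), concerns methoxy in place of hydrogen on an aromatic carbon and says nothing directly about the thiocarbonyl substituent.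

Compound 4 `CC1CCCCN1C(=S)SCc1ccc(C(=O)Nc2ccccc2N)cc1` is unmeasured. It differs from compound 2 by 2-methylpiperidin-1-yl in place of methyl(pyridin-3-yl)amino on a thiocarbonyl carbon. For the measured compounds named here, no measured step touches this position; compounds 1 and 2 carry different groups on the thiocarbonyl carbon and give numbers within the scatter of each other, which is the only hint that this end tolerates variation. The expectation for this assay is a step of a number 12.5 percentage points lower from compound 2 to compound 4 (beyond the scatter), possibly slightly downward, with wide uncertainty. Compound 4 is estimated at 70%, expected within 35% to 90%.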

Compound 4, a percentage reported as inhibition, at one concentration (the size of the read-out at that concentration, not a potency): 86.9%
The estimate for compound 4 lay 16.9 percentage points below the measured number, and the stated range covers the measured number.
By their numbers in this assay, from the lowest: compound 3; then compounds 2, 4 and 1 (each within the scatter of the next).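

In this assay, among the compounds shown here, the step of a number 4.4 percentage points higher from compound 2 to compound 4 (within the scatter) is the only measured single-place change on the thiocarbonyl carbon, with 2-methylpiperidin-1-yl in place of methyl(pyridin-3-yl)amino. This change replaces a six-membered aromatic ring with a six-membered non-aromatic ring and does not separate the two compounds at the single concentration tested, so an aromatic ring on this amino group is not needed for a read-out of this size in this pair. No measured evidence on hand explains the result.

The compounds shown leave open whether the 2-methyl group matters, since the plain piperidin-1-yl group does not appear among them. They also leave open whether morpholin-4-yl, with its ring oxygen, or open-chain diethylamino would be tolerated at this position.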